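The compounds below may be only part of what the source reports. "The series", "measured", "known", "first", "only" and "open" are said of these compounds alone.

Of the compounds shown here, three built on one shared core have been tested in an assay on CHO-K1 cells for displacement of a labelled ligand from adenosine receptor A1 (Homo sapiens); a higher number here means a weaker inhibitor, a lower number a stronger inhibitor. Compound 1 `CCCn1c(=O)c2nc([C@H]3CC[C@H](CO)CC3)[nH]c2n(CCC)c1=O` gives 41 nM. Compound 2 `CCCCNC(=O)[C@H]1CC[C@H](c2nc3c(=O)n(CCC)c(=O)n(CCC)c3[nH]2)CC1` carries butylcarbamoyl where compound 1 carries hydroxymethyl; in this assay compound 2 gives 46 nM. That change, a 1.1-fold higher number from compound 1 to compound 2 (0.05 log units; within the scatter), is within the scatter. Compound 3 `CCCn1c(=O)c2nc([C@]34CC[C@](C(=O)NCCN(C)C)(CC3)CC4)[nH]c2n(CCC)c1=O` gives 6 nM, the lowest number of the three; its gaps to compound 1 and to compound 2 are both beyond the scatter, so compound 3 is the strongest inhibitor of those measured.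

Compound 4 `CCCn1c(=O)c2nc([C@]34CC[C@](C(=O)NCC(=O)O)(CC3)CC4)[nH]c2n(CCC)c1=O` differs from compound 3 in one place: carboxy in place of (dimethylamino)methyl on a saturated chain carbon bound to an amide-type nitrogen. Among the compounds with values here, no measured step alters this side chain directly. Within the data shown here, the only single-change step at hand, from compound 1 to compound 2, swaps the group on a saturated ring carbon and lies within the scatter, so one exchange of a pendant group has left the number where it was. On that slender basis, a step no larger than the scatter is expected in this assay, with no firm direction. Compound 4 is therefore expected to give about 10 nM, with a range from 3 nM to 35 nM. This amounts to an expected step of a 1.7-fold higher number from compound 3 to compound 4 (0.22 log units; within the scatter).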

Compound 4, inhibition constant: 49 nM
Compound 4: the middle estimate sits 4.9-fold (0.69 log units) below what was measured; the whole stated range lies below it.
By their numbers in this assay, from the lowest: compound 3; then compounds 1, 2 and 4 (each within the scatter of the next).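

In this assay, within the data shown here, putting carboxy in place of (dimethylamino)methyl on a saturated chain carbon bound to an amide-type nitrogen gives an 8.2-fold higher number from compound 3 to compound 4 (0.91 log units; beyond the scatter) and is the first single exchange to move the number beyond the scatter. Among these compounds, the only earlier step, a 1.1-fold higher number from compound 1 to compound 2 (0.05 log units; within the scatter) for butylcarbamoyl in place of hydroxymethyl on a saturated ring carbon, had left the number unmoved, so the new step shows that an exchange of a pendant group is not always silent here and that the outer end of the (2-(dimethylamino)ethyl)carbamoyl side chain of compound 3 counts in this assay. No measurement at hand accounts for the size or direction of this step.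

With only these two end groups compared at this position, the step cannot be divided between the departure of the dimethylamino part and the arrival of the carboxy. Going by these compounds, how a primary amine, a methyl ester or a simple methyl at the same place would read stays open, as does the effect of a longer chain between the amide nitrogen and the end group.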